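Swapping the Aromatic Group on the Amine of Compound 1

The source may report more compounds than this note shows. Statements on the series, on what has been measured and on what is new or still open speak of the compounds shown alone.

Measured so far in a functional assay on KB cells (Homo sapiens) for cytotoxicity, read by sulforhodamine B assay; on this read-out lower numbers stand for stronger inhibition and higher numbers for weaker inhibition
compound 1 `C=C1[C@@H](OC(C)=O)C[C@@H]2[C@](C)(CO[Si](C)(C)C(C)(C)C)[C@H](OC(C)=O)CC[C@@]2(C)[C@@H]1C[C@@H](Nc1ccc(OC)c(OC)c1)C1=CCOC1=O` gives 5800 nM
compound 2 `C=C1[C@@H](OC(C)=O)C[C@@H]2[C@](C)(COC=O)[C@H](OC(C)=O)CC[C@@]2(C)[C@@H]1C[C@@H](Nc1ccc(O)cc1)C1=CCOC1=O` gives 28900 nM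
compound 3 `C=C1[C@@H](OC(C)=O)C[C@@H]2[C@](C)(COC=O)[C@H](OC(C)=O)CC[C@@]2(C)[C@@H]1C[C@@H](Nc1ccccc1C(=O)O)C1=CCOC1=O` gives 42500 nM

Compound 1 has the lowest number of the three, and its gaps to compound 2 and compound 3 both lie beyond the scatter, so it is the most potent of this small set. The next compound, compound 4 `C=C1[C@@H](OC(C)=O)C[C@@H]2[C@](C)(CO[Si](C)(C)C(C)(C)C)[C@H](OC(C)=O)CC[C@@]2(C)[C@@H]1C[C@@H](Nc1cccc(F)c1)C1=CCOC1=O`, keeps the core of compound 1 and changes one group: 3-fluorophenyl in place of 3,4-dimethoxyphenyl on an amine nitrogen.

Among the measured compounds shown here, only one measured step changes nothing but the aromatic group on that nitrogen. It shows a 1.5-fold higher number from compound 2 to compound 3 (0.17 log units; within the scatter) when 2-carboxyphenyl replaces 4-hydroxyphenyl, a different swap on a different version of the core, so it is only a loose guide. Compound 1 and compound 2 differ in more than the aromatic group, and their gap cannot be pinned on either change. No step beyond the scatter is therefore expected, and no clear direction. The estimate means an expected 1.0-fold higher number from compound 1 to compound 4 (0.01 log units; within the scatter) in this assay for this swap. Compound 4 is estimated at 6000 nM with 2500 nM to 15000 nM as the expected range.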

Compound 4, half-maximal inhibitory concentration: 4560 nM
Compound 4: the middle estimate sits 1.3-fold (0.12 log units) above what was measured, and the stated range covers the measured number.
By their numbers in this assay, from the lowest: compounds 4 and 1 (each within the scatter of the next); then compounds 2 and 3 (each within the scatter of the next).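

This step reads the aromatic group on the amine nitrogen on the core of compound 1 itself, and in this assay it shows a 1.3-fold lower number from compound 1 to compound 4 (0.10 log units; within the scatter). The change from 3,4-dimethoxyphenyl to 3-fluorophenyl removes both oxygen atoms and the 2 hydrogen-bond acceptors and takes the group from 10 heavy atoms to 7, yet the step stays within the scatter, so on this core the position accepts this exchange with no readable change in this assay. Nothing measured here accounts for the two groups reading alike.

Still open, on these data alone, is how much the aromatic ring on this nitrogen matters on this core, a question that a ring carrying an amine, or a plain butyl chain in place of the ring, would help to answer. Compound 1 and compound 2 also differ in more than the aromatic group, which leaves open how much of their gap belongs to the other change on the core.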